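The source may report more compounds than this note shows. Statements on the series, on what has been measured and on what is new or still open speak of the compounds shown alone.

Three compounds share one core, differing only in the aryl group attached to the carbon that carries a double bond to nitrogen. Compound 1 `O=C(N/N=C/c1ccccc1)c1cccnc1Nc1cccc(C(F)(F)F)c1` has a plain phenyl there, compound 2 `O=C(N/N=C/c1cccc(Cl)c1)c1cccnc1Nc1cccc(C(F)(F)F)c1` a 3-chlorophenyl, and compound 3 `COc1ccc(/C=N/NC(=O)c2cccnc2Nc2cccc(C(F)(F)F)c2)c(OC)c1` a 2,4-dimethoxyphenyl. In a functional assay on the whole organism (strain Wistar) for inhibition, with Rattus norvegicus as the target, read by paw edema, with a stated time of 1 h, at a dose of 10 mg/kg by the intraperitoneal route (a lower number here means less inhibition, a higher number more inhibition at the dose given (going by the name of the read-out)), compound 1 gives 53.9%, compound 2 gives 76.7%, and compound 3 gives 55.7%. Compound 2 stands highest of the three; the step of a number 22.8 percentage points higher from compound 1 to compound 2 (beyond the scatter) comes from chloro in place of hydrogen on an aromatic carbon, and the step of a number 21 percentage points lower from compound 2 to compound 3 (beyond the scatter) runs the other way, while compound 1 and compound 3 sit within the scatter of each other.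

Compound 4 `O=C(N/N=C/c1cccnc1)c1cccnc1Nc1cccc(C(F)(F)F)c1` is the next variation: pyridin-3-yl in place of 3-chlorophenyl on a carbon with a double bond to nitrogen. Both steps that bear on it show that leaving the 3-chlorophenyl of compound 2 for another aryl group costs a modest amount, whether the replacement is phenyl, as in the step of a number 22.8 percentage points higher from compound 1 to compound 2 (beyond the scatter) read from compound 2 downward, or 2,4-dimethoxyphenyl, as in the step of a number 21 percentage points lower from compound 2 to compound 3 (beyond the scatter). A pyridin-3-yl has no chlorine either, so a similar drop is expected, about a number 21.7 percentage points lower from compound 2 to compound 4 (beyond the scatter). Compound 4 is therefore estimated at 55%, with a likely range from 40% to 70%.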

Compound 4, a percentage reported as inhibition, in the whole organism at one dose (the size of the read-out at that dose, not a potency): 76.1%
Compound 4: middle estimate off by 21.1 percentage points, on the low side; measured number outside the range, above it.
By their numbers in this assay, from the lowest: compounds 1 and 3 (each within the scatter of the next); then compounds 4 and 2 (each within the scatter of the next).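

Replacing the 3-chlorophenyl with pyridin-3-yl does not shift the read-out (a number 0.6 percentage points lower from compound 2 to compound 4 (within the scatter)), so in this assay a chlorine on this aryl group is not required for the higher level. Pyridin-3-yl also stands apart from both phenyl (a number 22.2 percentage points higher from compound 1 to compound 4 (beyond the scatter)) and 2,4-dimethoxyphenyl (a number 20.4 percentage points higher from compound 3 to compound 4 (beyond the scatter)), so the divide among these four compounds does not run simply between chlorinated and chlorine-free groups. Nothing available here explains why two such different rings give matching numbers.

As far as these compounds go, it remains open whether pyridin-2-yl or pyridin-4-yl would match pyridin-3-yl, and whether 3-fluorophenyl or 3-methoxyphenyl would match 3-chlorophenyl. A saturated ring such as cyclohexyl at this position is also untested among the compounds shown, so the need for an aromatic ring there remains an open question.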